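Chloro on the oxindole-side ring of compound 1

The compounds below may be only part of what the source reports. "The series", "measured", "known", "first", "only" and "open" are said of these compounds alone.

Within the data shown here, compound 1 `COc1c(/C=C2/C(=O)Nc3ccccc32)c2ccccc2n1-c1ccccc1` is one of three compounds so far measured in a functional assay on NSCLC cells (Homo sapiens) for cytotoxicity, with a stated time of 48 h; a lower number here means a stronger inhibitor of growth, a higher number a weaker inhibitor of growth. In this assay compound 1 gives 2140 nM. Compound 2 `COc1ccc2c(c1)/C(=C\c1c(Cl)n(C/C=C/c3ccccc3)c3ccccc13)C(=O)N2` gives 2240 nM, a number that lies within the scatter of compound 1, so no order between the two can be read. Compound 3 `COc1ccc2c(c1)/C(=C\c1c(Cl)n(Cc3cc(OC)c(OC)c(OC)c3)c3cc(C)c(OC)cc13)C(=O)N2` gives 20400 nM, which is the furthest from compound 1 and sits well beyond the scatter. Compound 1 thus holds the lowest number of the three, though it cannot be called the strongest inhibitor of growth, since its gap to compound 2 is within the scatter.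

Compound 4 `COc1c(/C=C2/C(=O)Nc3ccc(Cl)cc32)c2ccccc2n1-c1ccccc1` is not yet measured. It differs from compound 1 by chloro in place of hydrogen on an aromatic carbon, placed on an aromatic carbon of a six-membered aromatic ring of carbon only, part of a fused system of two rings, meta to a fused ring and para to a fused ring. Among the measured compounds shown here, no pair of measured compounds that differ in one place exists in this set, so the size of this step cannot be read from data; a step of modest size, not clearly beyond the scatter, is expected. The step from compound 1 to compound 4 is estimated at a 1.3-fold lower number from compound 1 to compound 4 (0.13 log units; within the scatter). For compound 4 the expected value in this assay is 1600 nM, within a range from 500 nM to 5000 nM.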

Compound 4, concentration for 50% growth inhibition: 9550 nM
Compound 4: the middle estimate sits 6.0-fold (0.78 log units) below what was measured; measured number outside the range, above it.
By their numbers in this assay, from the lowest: compounds 1 and 2 (each within the scatter of the next); then compound 4; then compound 3.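

In this assay the series now has its first step in a single place: chloro in place of hydrogen on this aromatic carbon, meta to a fused ring and para to a fused ring, gives a 4.5-fold higher number from compound 1 to compound 4 (0.65 log units; beyond the scatter) and so weakens growth inhibition beyond the scatter. This carbon of the core of compound 1 is therefore not indifferent to substitution, since one chlorine atom is enough to shift the number. Nothing measured here bears on the reason for this shift.

From the compounds shown here alone, whether the loss is specific to chloro or follows any group at this carbon remains open, and fluoro, an amine or a carboxylic acid in the same place would help separate those readings. Also open, going by these compounds, is whether the same step holds on a core other than that of compound 1.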